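The source may hold more compounds than are shown below. What is called first, only, known or untested is meant among the compounds shown, and "the series" means these compounds.

Among the compounds with values here, in an in vivo ADME assay on the whole organism (strain CD-1) for pharmacokinetics, with Mus musculus as the target (a higher number here means that more of the compound sits outside the plasma, a lower number that more of the compound stays in the plasma), compound 1 `CCCS(=O)(=O)Nc1ccc(Cl)c(C(=O)Nc2cnc3[nH]nc(OC)c3c2)c1F` gives 0.11 L/kg and stands lowest of the three compounds measured so far. Compound 3 `CCCS(=O)(=O)Nc1ccc(F)c(C(=O)Nc2cnc3[nH]cc(Br)c3c2)c1F` gives 0.24 L/kg and compound 2 `CCCS(=O)(=O)Nc1ccc(F)c(C(=O)Nc2cnc3[nH]ncc3c2)c1F` gives 0.68 L/kg and both gaps to compound 1 lie beyond the usual scatter of repeat measurements.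

Compound 4 `CCCS(=O)(=O)Nc1ccc(F)c(C(=O)Nc2cnc3[nH]nc(OC)c3c2)c1F` has not been measured yet. It keeps the core of compound 1 and carries a single change. The change fluoro in place of chloro on an aromatic carbon puts fluoro in place of chloro on an aromatic carbon, para to a (propylsulfonyl)amino group.

Within the data shown here, no measured pair shows this swap alone, so its size can only be judged loosely. Compound 3 at 0.24 L/kg and compound 2 at 0.68 L/kg already carry fluoro at that place, but they also differ from compound 1 elsewhere in the core, so they give only a weak hint of a rise. A small upward step is expected, and the estimated move a 1.6-fold higher number from compound 1 to compound 4 (0.21 log units; within the scatter) may well stay within the scatter. The estimate for compound 4 is 0.18 L/kg with an expected range from 0.09 L/kg to 0.4 L/kg in repeat measurements.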

Compound 4, volume of distribution in the Mus musculus assay: 0.11 L/kg
The estimate for compound 4 lay 1.6-fold (0.21 log units) above the measured number, and the stated range covers the measured number.
By their numbers in the Mus musculus assay, from the lowest: compounds 1 and 4 (each within the scatter of the next); then compound 3; then compound 2.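

In the Mus musculus assay, fluoro in place of chloro, para to a (propylsulfonyl)amino group, shows no change at the digits printed from compound 1 to compound 4 (within the scatter), whereas methoxy in place of hydrogen on an aromatic carbon shows a 6.2-fold lower number from compound 2 to compound 4 (0.79 log units; beyond the scatter); of these two single changes, only the methoxy swap moves this read-out beyond the scatter. The halogen swap is not silent everywhere, though: in a physicochemical assay for solubility, read by HPLC, in phosphate buffer, with a stated time of 24 h, at pH 6.5 (on this read-out higher numbers stand for higher solubility and lower numbers for lower solubility), it gives an at least 4.0-fold higher number from compound 1 to compound 4 (0.60 log units; beyond the scatter). In the physicochemical assay compound 1 gives < 1 ug/mL, which is a limit of the assay and not a number, and the step rests on it: the limit of < 1 ug/mL in the physicochemical assay, at which 1 of the 2 values shown sits. In the physicochemical assay compound 4 gives 4 ug/mL.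

As far as these compounds go, it remains open whether a nitrile or a methyl group at this place would leave the Mus musculus assay just as unmoved. From the compounds shown here alone, it is also open how far the physicochemical assay would shift with such a group.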